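The source may report more compounds than this note shows. Statements on the series, on what has been measured and on what is new or still open speak of the compounds shown alone.

Compound 3 `Nc1nc(SCc2ccccc2)c2ncn(/C=C3/CC3(CO)CO)c2n1`, compound 1 `CCCCSc1nc(N)nc2c1ncn2/C=C1/CC1(CO)CO` and compound 2 `CN(C)c1nc(N)nc2c1ncn2/C=C1/CC1(CO)CO` share one core and differ only in the group attached to it. In an ADME assay on Akata cells (Homo sapiens) for cytotoxicity, with a stated time of 7 days (on this read-out lower numbers stand for higher toxicity in this test and higher numbers for lower toxicity in this test), compound 3 reaches only a limit, > 20000 nM. Compound 1 likewise gives a limit, > 20000 nM. Compound 2 also gives a limit, > 24000 nM. Compound 3 thus stands together with the other two at the edge of what this assay can report, as the limit of > 20000 nM in this assay, at which 2 of the 3 values shown sit, and the limit of > 24000 nM in this assay, at which 1 of the 3 values shown sits, show. Compound 4 `C=CCOc1nc(N)nc2c1ncn2/C=C1/CC1(CO)CO` differs from compound 3 in one place: allyloxy in place of benzylsulfanyl on an aromatic carbon. The steps a step that the two limits leave unreadable from compound 1 to compound 3 and a step that the two limits leave unreadable from compound 2 to compound 3 bear on this change, yet their size cannot be read. The estimated step of a number no higher from compound 3 to compound 4 (the limit leaves the size open) therefore means no change beyond the usual scatter. Compound 4 is expected to give 20000 nM, between 10000 nM and 40000 nM.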

Compound 4, half-maximal cytotoxic concentration: > 20000 nM
Compound 4 gave a limit, no number (the forecaster's own chance of this, stated with the estimate: 85%); the middle value sits exactly at the limit.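

Within the data shown here, compound 4, like compound 1, compound 2 and compound 3, gives only a limit, so no step between these compounds can be read: the limit of > 20000 nM in this assay, at which 3 of the 4 values shown sit. The compounds shown leave open how toxic each one is in this assay, and whether changing the group alters that toxicity.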